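Replacing the 1H-indazol-5-yl group of compound 3

The source may hold more compounds than are shown below. What is called first, only, known or untested is meant among the compounds shown, and "the series" means these compounds.

Measured in a functional assay on K562 cells (Homo sapiens) for inhibition, read by trypan blue exclusion, with a stated time of 72 h; on this read-out higher numbers stand for weaker inhibition and lower numbers for stronger inhibition:
- Compound 1 `Cn1c(=O)c(S(=O)(=O)c2ccc(F)cc2F)cc2cnc(Nc3ccc4[nH]c(C(=O)O)cc4c3)nc21`: 10000 nM
- Compound 2 `Cn1c(=O)c(S(=O)(=O)c2ccc(F)cc2F)cc2cnc(Nc3ccncn3)nc21`: 30000 nM
- Compound 3 `Cn1c(=O)c(S(=O)(=O)c2ccc(F)cc2F)cc2cnc(Nc3ccc4[nH]ncc4c3)nc21`: 50000 nM

Compound 3 lies at the high end of the measured range. The smallest step reaching it is a 1.7-fold higher number from compound 2 to compound 3 (0.22 log units; within the scatter), and the largest is a 5.0-fold higher number from compound 1 to compound 3 (0.70 log units; beyond the scatter).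

Compound 4 `Cn1c(=O)c(S(=O)(=O)c2ccc(F)cc2F)cc2cnc(Nc3ccc4c(c3)CC(=O)N4)nc21` is still unmeasured. It differs from compound 3 as follows: a group of 10 heavy atoms (8 carbon, 1 nitrogen, 1 oxygen; one five-membered non-aromatic ring with 1 hetero atom, one six-membered aromatic ring of carbon only) in place of a group of 9 heavy atoms (7 carbon, 2 nitrogen; one five-membered aromatic ring with 2 hetero atoms, one six-membered aromatic ring of carbon only), on a nitrogen on an aromatic ring. All three measured steps changed the group at this same place, and they stayed modest or smaller, with the remaining one being a 3.0-fold higher number from compound 1 to compound 2 (0.48 log units; beyond the scatter). No step beyond the scatter is therefore expected in this assay. The estimate for compound 4 is 35000 nM, with an expected range of 12000 nM to 90000 nM. This estimate means an expected 1.4-fold lower number from compound 3 to compound 4 (0.15 log units; within the scatter).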

Compound 4, half-maximal inhibitory concentration: 15000 nM
Beside the measured number, compound 4's estimate is 2.3-fold (0.37 log units) above it, within the range that was stated.
By their numbers in this assay, from the lowest: compounds 1, 4, 2 and 3 (each within the scatter of the next, the first and the last beyond it).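

In this assay, replacing the 1H-indazol-5-yl group with a group holding a five-membered non-aromatic ring gives a 3.3-fold lower number from compound 3 to compound 4 (0.52 log units; beyond the scatter) and shows that this position separates two groups that each hold a six-membered aromatic ring of carbon only. Against the other two compounds, a 2.0-fold lower number from compound 2 to compound 4 (0.30 log units; within the scatter) and a 1.5-fold higher number from compound 1 to compound 4 (0.18 log units; within the scatter) both stay within the scatter, so a number in this region does not depend on the carboxy group of compound 1. Nothing shown explains the step from the indazole.

As far as these compounds go, whether a piperazine or a morpholine at this position would give a number clearly lower than those of compound 1 and compound 4 remains open.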